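Branching the pentyl chain of compound 1

The compounds below may be only part of what the source reports. "The series", "measured", "known", "first", "only" and "open" are said of these compounds alone.

Compound 1 `CCCCCOCNc1n[n+]([O-])c2ccccc2[n+]1[O-]`: 9200 nM
Compound 2 `[O-][n+]1nc(NCOCc2ccc(C(F)(F)F)cc2)[n+]([O-])c2ccccc21`: 7650 nM
Compound 3 `CCCCCOCNc1n[n+]([O-])c2cc(OC)ccc2[n+]1[O-]`: 3630 nM

Of the compounds shown here, three have been measured in a functional assay on PC-3 cells (Homo sapiens) for cytotoxicity, read by MTT assay, with a stated time of 72 h; on this read-out higher numbers stand for weaker inhibition and lower numbers for stronger inhibition. Going by the values given here, compound 1 gives the highest number of the three; compound 2 sits within the scatter of it, while compound 3 sits beyond the scatter, the only step measured between two compounds differing in one place being a 2.5-fold lower number from compound 1 to compound 3 (0.40 log units; beyond the scatter), a methoxy in place of hydrogen on an aromatic carbon.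

Compound 4 `CC(C)CCOCNc1n[n+]([O-])c2ccccc2[n+]1[O-]` is still to be measured in this assay. It differs from compound 1 by isopropyl in place of propyl on a saturated chain carbon, two bonds along the chain from an oxygen on a saturated carbon. Among the compounds with values here, none of the measured steps touches the saturated chain; the one measured step concerns the aromatic ring and says nothing about branching the chain, and compound 2 carries a different chain altogether. With no evidence on this change, compound 4 is expected to lie close to compound 1, with a step of a 1.0-fold lower number from compound 1 to compound 4 (0.01 log units; within the scatter) not beyond the scatter. The estimate for compound 4 is 9000 nM, within 4500 nM to 18000 nM.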

Compound 4, half-maximal inhibitory concentration: 11100 nM
Beside the measured number, compound 4's estimate is 1.2-fold (0.09 log units) below it; low and high end bracket the measured number.
By their numbers in this assay, from the lowest: compound 3; then compounds 2, 1 and 4 (each within the scatter of the next).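

In this assay, the step on the saturated chain is a 1.2-fold higher number from compound 1 to compound 4 (0.08 log units; within the scatter), so isopropyl in place of propyl, two bonds along the chain from an oxygen on a saturated carbon, gives no difference that can be told from the scatter. Going by these compounds alone, the earlier compounds offered only one step, on the aromatic ring, and that one, a 2.5-fold lower number from compound 1 to compound 3 (0.40 log units; beyond the scatter), lies beyond the scatter, whereas this first reading on the chain does not. Nothing in the data bears on what lies behind this result.

On these data alone, whether a branch elsewhere on the chain, a longer chain such as heptyl, or an amine at the chain end would also stay within the scatter remains open. So does what isopropyl on the chain and methoxy on the aromatic ring would give together in one compound.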